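The source may hold more compounds than are shown below. What is called first, only, known or untested is meant among the compounds shown, and "the series" means these compounds.

Measured compounds in the series:

- compound 1, `O=C(C1=C(Nc2ccccc2)C(=O)N(CCCn2ccnc2)C1c1ccc(Br)cc1)c1ccccc1`: 25700 nM
- compound 2, `Cc1ccc(NC2=C(C(=O)c3ccccc3)C(c3ccc(Br)cc3)N(CCCn3ccnc3)C2=O)cc1`: 24100 nM
- compound 3, `O=C(C1=C(Nc2ccc(OC(F)(F)F)cc2)C(=O)N(CCCn2ccnc2)C1c1ccc(Br)cc1)c1ccccc1`: 11500 nM

In a functional assay on U2OS cells (Homo sapiens) for antiproliferative activity, read by MTT assay, with a stated time of 72 h (on this read-out higher numbers stand for weaker inhibition and lower numbers for stronger inhibition), compound 3 stands lowest of the three numbers, with a 2.2-fold lower number from compound 1 to compound 3 (0.35 log units; beyond the scatter) and a 2.1-fold lower number from compound 2 to compound 3 (0.32 log units; beyond the scatter) both modest and beyond the scatter, whereas a 1.1-fold lower number from compound 1 to compound 2 (0.03 log units; within the scatter) lies within the scatter. Compound 4, `O=C(C1=C(Nc2cccc(Br)c2)C(=O)N(CCCn2ccnc2)C1c1ccc(Br)cc1)c1ccccc1`, is not yet measured. Its change from compound 3 is 3-bromophenyl in place of 4-(trifluoromethoxy)phenyl on an amine nitrogen. Among the measured compounds shown here, no measured step covers this swap: the three steps seen concern trifluoromethoxy or methyl in place of hydrogen on an aromatic carbon, and the only one beyond the scatter is the gain from hydrogen to trifluoromethoxy. For the measured compounds named here, removing that group and bringing in 3-bromophenyl has no direct precedent, so the expectation in this assay rests on the spread of the three measured values: a step back toward the numbers of compound 1 and compound 2, small and uncertain. Compound 4 is therefore expected to read about 18000 nM, with a range from 7000 nM to 45000 nM, which would mean a step of a 1.6-fold higher number from compound 3 to compound 4 (0.19 log units; within the scatter).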

Compound 4, half-maximal inhibitory concentration: 11900 nM
Compound 4: the middle estimate sits 1.5-fold (0.18 log units) above what was measured; low and high end bracket the measured number.
By their numbers in this assay, from the lowest: compounds 3 and 4 (each within the scatter of the next); then compounds 2 and 1 (each within the scatter of the next).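

In this assay, the change to 3-bromophenyl from 4-(trifluoromethoxy)phenyl on the amine nitrogen gives a 1.0-fold higher number from compound 3 to compound 4 (0.01 log units; within the scatter) at this position, so these two aryl groups cannot be told apart here. Bromo in place of hydrogen gives a 2.2-fold lower number from compound 1 to compound 4 (0.33 log units; beyond the scatter) and 3-bromophenyl in place of 4-methylphenyl gives a 2.0-fold lower number from compound 2 to compound 4 (0.31 log units; beyond the scatter), showing that the modest step from the unsubstituted phenyl of compound 1 is not confined to 4-(trifluoromethoxy)phenyl, though compound 2 with its 4-methylphenyl goes against any general gain from substitution. No evidence is available on what lies behind these steps.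

Bromo and trifluoromethoxy differ in both group and ring position, so it remains open which of the two matters, as 4-bromophenyl and 3-(trifluoromethoxy)phenyl would show. Also open, going by these compounds, is how this position responds to a carboxylic acid or an amine on the phenyl ring.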